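Swapping chloro for fluoro on the pendant phenyl ring

The compounds below may be only part of what the source reports. "The series", "measured", "known", "first", "only" and "open" are said of these compounds alone.

Measured so far in an ADME assay on RWPE-1 cells (Homo sapiens) for cytotoxicity, read by MTT assay, with a stated time of 48 h; a lower number here means a stronger inhibitor, a higher number a weaker inhibitor:
Compound 1 `Cn1cc(/C=C2/C(=O)Nc3ccccc32)c2cc(Nc3nccc(-c4ccccc4)n3)ccc21`: compound 1 gives 95600 nM
Compound 2 `Cn1cc(/C=C2/C(=O)Nc3ccccc32)c2cc(Nc3nccc(-c4ccc(O)cc4)n3)ccc21`: compound 2 gives 58400 nM
Compound 3 `Cn1cc(/C=C2/C(=O)Nc3ccccc32)c2cc(Nc3nccc(-c4ccc(Cl)cc4)n3)ccc21`: compound 3 gives 41100 nM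

Compound 3 holds the lowest number of the three; only its gap to compound 1 lies beyond the scatter. Compound 4 `Cn1cc(/C=C2/C(=O)Nc3ccccc32)c2cc(Nc3nccc(-c4ccc(F)cc4)n3)ccc21` differs from it by fluoro in place of chloro on an aromatic carbon. Within the data shown here, two steps bear on this: a 2.3-fold lower number from compound 1 to compound 3 (0.37 log units; beyond the scatter) and a 1.4-fold lower number from compound 2 to compound 3 (0.15 log units; within the scatter). Both halogen-bearing compounds sit at the low end, and the change from hydrogen to chloro was only modest, so a change between two halogens is expected to be small. The step from compound 3 to compound 4 in this assay is estimated at a 1.5-fold higher number from compound 3 to compound 4 (0.16 log units; within the scatter). Compound 4 is therefore expected to give about 60000 nM, in a range from 35000 nM to 100000 nM.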

Compound 4, half-maximal inhibitory concentration: 168000 nM
Beside the measured number, compound 4's estimate is 2.8-fold (0.45 log units) below it; the measured number lies above the stated range.
By their numbers in this assay, from the lowest: compounds 3, 2, 1 and 4 (each within the scatter of the next, the first and the last beyond it).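

Here the choice of halogen matters: in this assay, the two are not interchangeable at this position on the pendant phenyl ring (a 4.1-fold higher number from compound 3 to compound 4 (0.61 log units; beyond the scatter)). Fluoro also separates from hydroxy (a 2.9-fold higher number from compound 2 to compound 4 (0.46 log units; beyond the scatter)), yet it cannot be told apart from plain hydrogen (a 1.8-fold higher number from compound 1 to compound 4 (0.24 log units; within the scatter)), so among these compounds, fluoro does not share the shift seen with chloro. No evidence is available to explain this difference between the halogens.

Going by these compounds, whether bromo, a methoxy group, an amine or a carboxylic acid at this position would track chloro or fluoro remains open.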